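The compounds below may be only part of what the source reports. "The series", "measured", "known", "first", "only" and "open" are said of these compounds alone.

Compound 3 `Cc1cccc(-n2cc(-c3ccc(NS(=O)(=O)c4c[nH]c(=O)[nH]c4=O)cc3)nn2)c1` gives the highest number of the three in a functional assay on SGC-7901 cells (Homo sapiens) for antiproliferative activity, read by MTT assay, with a stated time of 24 h (a higher number here means a weaker inhibitor, a lower number a stronger inhibitor), at 17500 nM. Compound 1 `O=c1[nH]cc(S(=O)(=O)Nc2ccccc2-c2cn(-c3ccccc3)nn2)c(=O)[nH]1` gives 11800 nM, which lies within the scatter of compound 3; compound 2 `O=c1[nH]cc(S(=O)(=O)Nc2ccccc2-c2cn(-c3cccc(Cl)c3)nn2)c(=O)[nH]1` gives 2270 nM, which lies beyond the scatter from compound 3. Compound 4 `O=c1[nH]cc(S(=O)(=O)Nc2ccc(-c3cn(-c4ccc(Cl)cc4)nn3)cc2)c(=O)[nH]1` differs from compound 3 by 4-chlorophenyl in place of 3-methylphenyl on an aromatic nitrogen. Within the data shown here, the only measured step that bears on a chlorine entering the phenyl on the aromatic nitrogen is a 5.2-fold lower number from compound 1 to compound 2 (0.72 log units; beyond the scatter), a modest lowering, though there chlorine replaced hydrogen rather than methyl. A somewhat smaller lowering is expected for compound 4 because a 5.2-fold lower number from compound 1 to compound 2 (0.72 log units; beyond the scatter) points that way, giving an expected step of a 2.5-fold lower number from compound 3 to compound 4 (0.40 log units; beyond the scatter) in this assay. Compound 4 is estimated at 7000 nM, with a range from 2500 nM to 20000 nM.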

Compound 4, half-maximal inhibitory concentration: 1830 nM
Beside the measured number, compound 4's estimate is 3.8-fold (0.58 log units) above it; measured number below the stated range.
By their numbers in this assay, from the lowest: compounds 4 and 2 (each within the scatter of the next); then compounds 1 and 3 (each within the scatter of the next).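

In this assay, a 9.6-fold lower number from compound 3 to compound 4 (0.98 log units; beyond the scatter) follows 4-chlorophenyl replacing 3-methylphenyl on the aromatic nitrogen, so this position responds to an exchange that leaves the heavy-atom count of the group unchanged. Unlike the earlier chlorine step, this one changes both the substituent and its place on the phenyl, and the two effects cannot be separated here. No measurement on hand accounts for the step. Still open, as far as these compounds go, is how 4-methylphenyl or 3-chlorophenyl would read on the core of compound 3, which would separate atom from place. Also open, from the compounds shown here alone, is whether 4-methoxyphenyl at this position would follow 4-chlorophenyl.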